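The source may report more compounds than this note shows. Statements on the series, on what has been measured and on what is new or still open speak of the compounds shown alone.

Two compounds anchor this short series. Compound 1 `COc1cc(-c2cc(/C=C/C(=O)c3ccc(N)cc3)[nH]n2)cc(OC)c1OC` carries a 4-aminophenyl group on the carbonyl carbon, and in a functional assay on MDA-MB-231 cells (Homo sapiens) for inhibition, read by MTT assay, with a stated time of 48 h (a higher number here means a weaker inhibitor, a lower number a stronger inhibitor), compound 1 gives 2000 nM. Its companion, compound 2 `COc1ccc(-c2cc(/C=C/C(=O)c3ccc(OC)c(OC)c3)[nH]n2)cc1`, differs in more than one place and gives 600 nM in this assay. Of the two numbers, compound 1 holds the higher one; the gap to compound 2 is beyond the scatter, so compound 1 is the weaker inhibitor of the pair.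

Within the data shown here, the next compound, compound 3 `COc1ccc(C(=O)/C=C/c2cc(-c3cc(OC)c(OC)c(OC)c3)n[nH]2)cc1F`, keeps the core of compound 1 and changes only one group: 3-fluoro-4-methoxyphenyl in place of 4-aminophenyl on a carbonyl carbon. Among the measured compounds shown here, no measured pair in this set isolates exactly this exchange, so its effect cannot be read off directly.

Still, an expectation can be formed. Compound 2 shows that a methoxy-bearing aryl on the carbonyl carbon sits at 600 nM, and compound 3 brings a related methoxy-bearing aryl to the same position. In this assay compound 3 is therefore expected to give 1000 nM, with a plausible range from 300 nM to 4000 nM. That estimate means a step of a 2.0-fold lower number from compound 1 to compound 3 (0.30 log units; within the scatter), a modest gain that could still fall within the scatter.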

Compound 3, half-maximal inhibitory concentration: 2700 nM
Estimate against measurement, compound 3: 2.7-fold (0.43 log units) below; measured number inside the range.
By their numbers in this assay, from the lowest: compound 2; then compounds 1 and 3 (each within the scatter of the next).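

Exchanging 4-aminophenyl for 3-fluoro-4-methoxyphenyl on a carbonyl carbon gives, in this assay, a 1.4-fold higher number from compound 1 to compound 3 (0.13 log units; within the scatter), so the two compounds cannot be told apart in this read-out. Among these compounds, this is the first comparison that changes a single place, and it shows that this position can hold either of two quite different aryl groups without a difference beyond the scatter: 4-aminophenyl carries a hydrogen-bond donor, whereas 3-fluoro-4-methoxyphenyl carries none and brings a fluorine and a methoxy group. No supporting measurement is available to explain why these two groups read alike.

The separate contributions of the fluorine and the methoxy group remain unresolved, and a simple 4-hydroxyphenyl or 4-carboxyphenyl group on the carbonyl carbon would test how far this tolerance extends. Compound 2 differs from the other two compounds in more than one place, so its lower number cannot yet be assigned to any single group.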